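A few compounds are considered here, and "the series" means these few. Any claim that something is new, unique, unknown or untested is made for them only; others in the source may bear on it.

Working notes on the series, read in a functional assay on cells (Homo sapiens) for cytotoxicity, read by resazurin assay, with a stated time of 72 h; a higher number here means a weaker inhibitor, a lower number a stronger inhibitor. Compound 1 (`COc1cc(/C=C/C(=O)OCCCO[N+](=O)[O-])ccc1OCCCO[N+](=O)[O-]`) gives > 50000 nM, which is a limit of the assay and not a number. Among the measured compounds shown here, compound 2 (`O=C(/C=C/c1ccc(O)c(O)c1)OCc1c(-c2ccccc2)no[n+]1[O-]`) gives 9170 nM, the only actual number so far, so it has no measured neighbour to be ranked against. Compound 3 (`COc1cc(/C=C/C(=O)OCc2c(-c3ccccc3)no[n+]2[O-])ccc1O`) is still unmeasured in this assay. It differs from compound 2 by methyl in place of hydrogen on an oxygen on an aromatic ring, turning 3,4-dihydroxyphenyl into 4-hydroxy-3-methoxyphenyl. For the measured compounds named here, no measured pair shows the size of this change, so the anchor is compound 2 at 9170 nM alone. The step of a 1.5-fold higher number from compound 2 to compound 3 (0.18 log units; within the scatter) is expected to be small, leaning towards weaker inhibition and possibly no larger than the scatter. For compound 3 the estimated value is 14000 nM, with an expected range of 5000 nM to 40000 nM.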

Compound 3, half-maximal inhibitory concentration: 16500 nM
Compound 3: middle estimate off by 1.2-fold (0.07 log units), on the low side, within the range that was stated.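

In this assay, methyl in place of hydrogen on an oxygen on an aromatic ring gives a 1.8-fold higher number from compound 2 to compound 3 (0.26 log units; within the scatter), the only size so far for any single change in the series. At this position, then, hydroxy to methoxy, or 3,4-dihydroxyphenyl to 4-hydroxy-3-methoxyphenyl, leaves the read-out within the scatter, and the free hydroxy on the other side of the change is not needed to keep compound 3 level with compound 2. Compound 1 differs in more than one place from the other two, so no step to it can be read, and its value is a limit and not a number: the limit of > 50000 nM in this assay, at which 1 of the 3 values shown sits.

The compounds shown leave open whether a longer chain on the same oxygen would stay as close to compound 2. Going by these compounds, an amine or a carboxylic acid at that place is equally open, as is a methoxy in place of the remaining hydroxy.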